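Thiophene to pyrazine on a tetrahydroquinoline amide

The source may hold more compounds than are shown below. What is called first, only, known or untested is meant among the compounds shown, and "the series" means these compounds.

For the measured compounds named here, compound 2 `CN1CCCc2ccc(NC(=O)c3ccc(-c4cccs4)cc3)cc21` is one of two compounds measured in a functional assay for antagonist activity at transient receptor potential cation channel subfamily V member 1 (Homo sapiens), read by FLIPR and calcium flux (on this read-out higher numbers stand for higher potency (the scale is a negative logarithm) and lower numbers for lower potency), where compound 2 gives 7.6, the only number recorded. Compound 1 `CN1CCCc2ccc(NC(=O)c3cccc(-c4ccccc4)c3)cc21` gives < 6.8 in this assay, which is a limit and not a number (the limit of < 6.8 in this assay, at which 1 of the 2 values shown sits). Compound 3 `CN1CCCc2ccc(NC(=O)c3ccc(-c4cnccn4)cc3)cc21` differs from compound 2 by pyrazin-2-yl in place of thiophen-2-yl on an aromatic carbon. Going by the values given here, no measured step covers this change, so the expected step from compound 2 to compound 3 is a number 0.60 log units lower from compound 2 to compound 3 (beyond the scatter), a modest loss that reaches beyond the scatter. For compound 3 the estimate in this assay is 7, with a range from 6.4 to 7.6.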

Compound 3, negative logarithm of the antagonist equilibrium constant: 7.1
Beside the measured number, compound 3's estimate is 0.10 log units below it, and the stated range covers the measured number.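

In this assay the position para to a large group accepts a six-membered aromatic ring with 2 hetero atoms in place of a five-membered one at a modest cost (a number 0.50 log units lower from compound 2 to compound 3 (beyond the scatter)). Potency therefore does not depend on the thiophen-2-yl group or its sulfur alone. Compound 3 still gives a number and not a limit, unlike compound 1, whose value is a limit: the limit of < 6.8 in this assay, at which 1 of the 3 values shown sits.

The compounds shown do not separate ring size from the identity of the hetero atoms. A furan-2-yl or pyridin-2-yl group on the same carbon would bear on that question.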